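Repositioning fluorines on the aryl group of compound 2

The source may report more compounds than this note shows. Statements on the series, on what has been measured and on what is new or still open speak of the compounds shown alone.

Measured compounds:
compound 1 `COc1cccc(F)c1C1CCN(c2ccn3c(CC4CC4)nnc3c2Cl)CC1`: 6 nM
compound 2 `COc1c(C2CCN(c3ccn4c(CC5CC5)nnc4c3Cl)CC2)ccc(F)c1F`: 26 nM

In a functional assay on CHO cells for agonist activity at metabotropic glutamate receptor 2 (Homo sapiens), read by scintillation counting and GTPgammaS binding, with a stated time of 30 min (on this read-out lower numbers stand for an effect already at smaller amounts and higher numbers for an effect only at larger amounts of compound), compound 1 gives 6 nM and compound 2 gives 26 nM. Among the compounds with values here, compound 2 therefore stands with the higher of the two numbers; the only step to it, a 4.3-fold higher number from compound 1 to compound 2 (0.64 log units; beyond the scatter), carries a 3,4-difluoro-2-methoxyphenyl in place of a 2-fluoro-6-methoxyphenyl on a saturated ring carbon.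

Compound 3 `COc1ccc(F)c(F)c1C1CCN(c2ccn3c(CC4CC4)nnc3c2Cl)CC1` has not yet been measured. It differs from compound 2 in one place: 2,3-difluoro-6-methoxyphenyl in place of 3,4-difluoro-2-methoxyphenyl on a saturated ring carbon. Within the data shown here, the entering group, 2,3-difluoro-6-methoxyphenyl, shares with the aryl group of compound 1 its methoxy and one of its fluorines, and the one measured step, a 4.3-fold higher number from compound 1 to compound 2 (0.64 log units; beyond the scatter), bears on it only indirectly. On that basis the estimated step is a 2.6-fold lower number from compound 2 to compound 3 (0.41 log units; beyond the scatter), a move back toward compound 1 in this assay.

Compound 3 is expected to give about 10 nM, with a range from 3 nM to 35 nM.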

Compound 3, half-maximal effective concentration: 9.3 nM
Compound 3: the middle estimate sits 1.1-fold (0.03 log units) above what was measured, within the range that was stated.
By their numbers in this assay, from the lowest: compounds 1 and 3 (each within the scatter of the next); then compound 2.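

In this assay, the change from the 3,4-difluoro-2-methoxyphenyl to the 2,3-difluoro-6-methoxyphenyl gives a 2.8-fold lower number from compound 2 to compound 3 (0.45 log units; beyond the scatter) while the atoms stay the same, so the arrangement of the fluorines and the methoxy on the aryl group alone is enough to shift the number. Fluoro in place of hydrogen on the aryl group of compound 1 gives a 1.6-fold higher number from compound 1 to compound 3 (0.19 log units; within the scatter) and so does not separate the two compounds, which shows that carrying a second fluorine does not by itself go with the higher number of compound 2. Nothing available here explains why the arrangement of these groups matters.

Going by these compounds, whether chloro or a nitrile could stand in place of either fluorine with a similar result remains open. So does the effect of an ethoxy in place of the methoxy.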